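A few compounds are considered here, and "the series" means these few. Any claim that something is new, unique, unknown or untested is made for them only; others in the source may bear on it.

Among the measured compounds shown here, compound 1 `O=c1nc(NCc2ccccc2)oc2c([N+](=O)[O-])cc(C(F)(F)F)cc12` is one of three compounds so far tested in an ADME assay on Vero cells (Chlorocebus sabaeus) for cytotoxicity, read by MTT assay, with a stated time of 48 h; a higher number here means a weaker inhibitor, a lower number a stronger inhibitor. In this assay, for the measured compounds named here, compound 1 gives 25.4 ug/mL, the only plain number among the three results. Compound 3 `COc1ccc(CNc2cc(=O)c3cc(C(F)(F)F)cc([N+](=O)[O-])c3s2)cc1OC` carries the same trifluoromethyl and nitro groups, but the difference between the two cores is not broken down here. For compound 3 in this assay the assay reports only a limit, > 64 ug/mL. Compound 2 `COc1ccc(CN(C)c2cc(=O)c3cc(C(F)(F)F)cc([N+](=O)[O-])c3s2)cc1OC` differs from compound 3 in one place, (methyl in place of hydrogen on a nitrogen on an aromatic ring). For compound 2 the outcome in this assay is also a limit, > 64 ug/mL. Going by the values given here, both results sit at the limit of > 64 ug/mL in this assay, at which 2 of the 3 values shown sit, so the step that the two limits leave unreadable from compound 3 to compound 2 has no readable size: the two measurements show only that neither compound reached the measurable range.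

Compound 4 `CN(Cc1ccccc1)c1nc(=O)c2cc(C(F)(F)F)cc([N+](=O)[O-])c2o1` has not yet been measured. It stands to compound 1 exactly as compound 2 stands to compound 3, namely by methyl in place of hydrogen on a nitrogen on an aromatic ring, the same change at the same kind of place. Among the compounds with values here, the one measured instance of this change yields no number for its size, and compound 1 is the only compound with a number in this assay. The expectation for compound 4 therefore rests on compound 1 and its value of 25.4 ug/mL, with a broad margin to allow for a shift in either direction. A step of a 1.3-fold higher number from compound 1 to compound 4 (0.10 log units; within the scatter) is expected. Compound 4 is expected to give 32 ug/mL in this assay, estimated to fall between 14 ug/mL and 70 ug/mL.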

Compound 4, half-maximal inhibitory concentration: 3.84 ug/mL
Beside the measured number, compound 4's estimate is 8.3-fold (0.92 log units) above it, and the stated range ends above it.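

In this assay, going from benzylamino to benzyl(methyl)amino on the core of compound 1 gives a 6.6-fold lower number from compound 1 to compound 4 (0.82 log units; beyond the scatter), so on this core a methyl in place of a hydrogen on that nitrogen moves the result beyond the usual scatter. The same change on the core of compound 3 cannot be read, because both members of that pair stand at a limit of the assay and not at a number: the limit of > 64 ug/mL in this assay, at which 2 of the 4 values shown sit. The series therefore holds a single sized instance of this change, which shows what it did on one core but does not show whether the result carries over to the other core, in either direction.

The compounds shown leave open whether an ethyl group, a longer chain or an acetyl group on the same nitrogen would shift the number on the core of compound 1 as methyl does, or whether the step is particular to methyl. They also leave open whether any group on that nitrogen, such as an ethyl group, would bring the core of compound 3 to a plain number in this assay, which is what a comparison between the two cores would need.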